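A Fluorine Moved Around the Ring: Compound 3 to Compound 4

The compounds below may be only part of what the source reports. "The series", "measured", "known", "first", "only" and "open" are said of these compounds alone.

Three compounds have so far been measured in an assay on CHO cells for displacement of a labelled ligand from adenosine receptor A2b (Homo sapiens), read by scintillation counting, with a stated time of 75 min, in the presence of a further agent that is not named here; a lower number here means a stronger inhibitor, a higher number a weaker inhibitor:

Compound 1 `CCCn1c(=O)[nH]c2nc(-c3ccc(S(=O)(=O)N4CCN(Cc5ccc(Br)cc5)CC4)cc3)[nH]c2c1=O` gives 0.153 nM.
Compound 2 `CCCn1c(=O)[nH]c2nc(-c3ccc(S(=O)(=O)N4CCN(c5cccc(F)c5)CC4)cc3)[nH]c2c1=O` gives 0.632 nM.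
Compound 3 `CCCn1c(=O)[nH]c2nc(-c3ccc(S(=O)(=O)N4CCN(c5ccc(F)cc5)CC4)cc3)[nH]c2c1=O` gives 0.644 nM.

Compound 3 carries the highest number of the three. Its separation from compound 2 is a 1.0-fold higher number from compound 2 to compound 3 (0.01 log units; within the scatter), so no order can be drawn between these two. Compound 1, by contrast, lies clearly lower: a 4.2-fold higher number from compound 1 to compound 3 (0.62 log units; beyond the scatter) and, for the other aryl partner, a 4.1-fold higher number from compound 1 to compound 2 (0.62 log units; beyond the scatter), both modest but beyond the scatter.

Compound 4 `CCCn1c(=O)[nH]c2nc(-c3ccc(S(=O)(=O)N4CCN(c5ccccc5F)CC4)cc3)[nH]c2c1=O` differs from compound 3 in one place: 2-fluorophenyl in place of 4-fluorophenyl on an amine nitrogen in a ring. Among the compounds with values here, the step that bears most directly on this change is the one between compound 2 and compound 3, where the fluorine likewise moved to another position of the same phenyl group and the result was a 1.0-fold higher number from compound 2 to compound 3 (0.01 log units; within the scatter), that is, no movement at all. The two steps from compound 1 involve a different kind of group on the ring nitrogen and speak less directly to the present change.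

On that basis compound 4 is expected to land close to compound 3, with a step of about a 1.1-fold higher number from compound 3 to compound 4 (0.04 log units; within the scatter), not beyond the scatter. The estimate for compound 4 is 0.7 nM, with a range from 0.3 nM to 1.8 nM.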

Compound 4, inhibition constant: 3.22 nM
Beside the measured number, compound 4's estimate is 4.6-fold (0.66 log units) below it; measured number outside the range, above it.
By their numbers in this assay, from the lowest: compound 1; then compounds 2 and 3 (each within the scatter of the next); then compound 4.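

In this assay, within the data shown here, the place of the fluorine on the phenyl group does matter, which the earlier compounds gave no sign of: the only such move seen before was (a 1.0-fold higher number from compound 2 to compound 3 (0.01 log units; within the scatter)). Putting 2-fluorophenyl in place of 4-fluorophenyl gives (a 5.0-fold higher number from compound 3 to compound 4 (0.70 log units; beyond the scatter)), and putting it in place of 3-fluorophenyl gives (a 5.1-fold higher number from compound 2 to compound 4 (0.71 log units; beyond the scatter)), so with the same atoms joined differently, the 2-fluorophenyl compound stands apart from the other two fluorophenyl compounds. Among these compounds, its distance from the 4-bromobenzyl compound is also the only large step in the set (a 21-fold higher number from compound 1 to compound 4 (1.32 log units; beyond the scatter)), and nothing available here accounts for the separate standing of the 2-fluorophenyl group.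

The compounds shown leave open whether this step belongs to fluorine in particular or would also appear with another group in its place, such as 2-chlorophenyl, 2-methylphenyl or 2-methoxyphenyl, and how plain unsubstituted phenyl would compare with all three fluorophenyl groups. They also leave open whether moving a halogen around the ring of a benzyl group, as in 2-bromobenzyl or 3-bromobenzyl, would give a step of similar size.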